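The source may hold more compounds than are shown below. What is called first, only, known or untested is meant among the compounds shown, and "the series" means these compounds.

The series shares the core seen in compound 1 `C/C(=C\c1cc2ccc(C)cc2nc1Cl)C(=O)c1cccc(Cl)c1`, a chloro-substituted quinoline bearing an unsaturated ketone arm, and the compounds were examined in an ADME assay on MCF7 cells (Homo sapiens) for cytotoxicity, read by MTT assay, with a stated time of 48 h; a lower number here means a stronger inhibitor, a higher number a weaker inhibitor. Compound 1 itself has no result in this assay, standing at "not determined" (no result reported). Compound 2 `Cc1ccc2cc(/C=C/C(=O)c3ccccn3)c(Cl)nc2c1` gives 75700 nM in this assay. Compound 3 `O=C(/C=C/c1cc2ccccc2nc1Cl)c1ccc(Cl)cc1` reaches only a limit of this assay, reported as > 100000 nM. Taken together, the values that exist sit at the weak end of what this assay can resolve, with one of them resting at the limit of > 100000 nM in this assay, at which 1 of the 3 values shown sits.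

Compound 4 `C/C(=C\c1cc2ccc(C)cc2nc1Cl)C(=O)c1cccc(Br)c1` is the unmeasured partner of compound 1. The difference between them, counted from the two structures, is bromo in place of chloro on an aromatic carbon, a 3-chlorophenyl becoming a 3-bromophenyl on the aromatic carbon meta to the large group. Among the measured compounds shown here, no measured pair in this set carries that change, so no step size can be read from the data; given how weak compound 2 and compound 3 are, no shift beyond the usual scatter is expected in either direction. Compound 4 is therefore estimated at 80000 nM, in the range from 30000 nM to 200000 nM, with a real chance that only a limit is returned.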

Compound 4, half-maximal inhibitory concentration: > 100000 nM
Compound 4 was reported as a limit; the forecaster's own chance of this, stated with the estimate: 45%; at least 1.2-fold (0.09 log units) between middle value and limit.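

Compound 1 has no result in this assay, and compound 4 gives only a limit, > 100000 nM, so no step can be read between compound 1 and compound 4. The compounds shown leave open whether 3-chlorophenyl to 3-bromophenyl changes the read-out at all, with several values resting at a limit: the limit of > 100000 nM in this assay, at which 2 of the 4 values shown sit.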